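Working notes: from compound 2 to compound 4

The source may hold more compounds than are shown below. What is called first, only, known or untested is meant among the compounds shown, and "the series" means these compounds.

Values are from a functional assay on HL-60 cells (Homo sapiens) for antiproliferative activity, read by MTT assay, with a stated time of 72 h; a lower number here means a stronger inhibitor, a higher number a weaker inhibitor.
compound 1 `COc1cc(C(=O)c2sc3ccccc3c2-c2ccc(C)cc2)cc(OC)c1OC` gives 1400 nM
compound 2 `COc1ccc(-c2c(C(=O)c3cc(OC)c(OC)c(OC)c3)sc3ccccc23)cc1` gives 1600 nM
compound 3 `COc1cc(C(=O)c2sc3ccccc3c2Nc2ccccc2)cc(OC)c1OC` gives 5200 nM

Compound 2 stands second highest of the three numbers; its nearest neighbour is compound 1, where a 1.1-fold higher number from compound 1 to compound 2 (0.06 log units; within the scatter), and its furthest is compound 3, where a 3.3-fold higher number from compound 2 to compound 3 (0.51 log units; beyond the scatter).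

Compound 4 `CCOc1ccc(Nc2c(C(=O)c3cc(OC)c(OC)c(OC)c3)sc3ccccc23)cc1` carries the change ((4-ethoxyphenyl)amino in place of 4-methoxyphenyl on an aromatic carbon). Going by the values given here, the steps that bear on it are a 3.3-fold higher number from compound 2 to compound 3 (0.51 log units; beyond the scatter) and a 3.7-fold higher number from compound 1 to compound 3 (0.57 log units; beyond the scatter), both modest rises beyond the scatter when an anilino group takes the place of an aryl group. Among the compounds with values here, no measured pair shows the effect of the ethoxy on the anilino group, so a rise of the same kind is expected for compound 4, a 2.8-fold higher number from compound 2 to compound 4 (0.45 log units; beyond the scatter). Compound 4 is therefore estimated at 4500 nM, within 1800 nM to 12000 nM.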

Compound 4, half-maximal inhibitory concentration: 500 nM
The estimate for compound 4 lay 9.0-fold (0.95 log units) above the measured number; measured number below the stated range.
By their numbers in this assay, from the lowest: compound 4; then compounds 1 and 2 (each within the scatter of the next); then compound 3.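

In this assay an anilino group at this position is not in itself a loss: adding ethoxy to it gives a 10-fold lower number from compound 3 to compound 4 (1.02 log units; beyond the scatter) and is the largest step in the series. The (4-ethoxyphenyl)amino group also improves on both directly attached aryl groups, with a 3.2-fold lower number from compound 2 to compound 4 (0.51 log units; beyond the scatter) and a 2.8-fold lower number from compound 1 to compound 4 (0.45 log units; beyond the scatter) as the printed steps. This reverses the rise seen with the unsubstituted anilino group of compound 3.

As far as these compounds go, whether ethoxy itself matters remains open; methoxy or a longer butoxy chain on the anilino ring would test this. No measured evidence accounts for the gain.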